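Working notes: from compound 3 to compound 4

The source may report more compounds than this note shows. Statements on the series, on what has been measured and on what is new or still open speak of the compounds shown alone.

Values in a functional assay on MDA-MB-231 cells (Homo sapiens) for antiproliferative activity, read by sulforhodamine B assay, with a stated time of 72 h; a lower number here means a stronger inhibitor, a higher number a weaker inhibitor:
- Compound 1 `COc1ncc(-c2ccc3c(c2)N(Cc2ccc(F)cc2)C(=O)CO3)cc1NS(=O)(=O)c1ccc(F)cc1F` at 4980 nM
- Compound 2 `COc1ncc(-c2ccc3c(c2)N(Cc2ccncc2)C(=O)CO3)cc1NS(=O)(=O)c1ccc(F)cc1F` at 5490 nM
- Compound 3 `CCCCS(=O)(=O)Nc1cc(-c2ccc3c(c2)N(Cc2ccncc2)C(=O)CO3)cnc1OC` at 37900 nM

Compound 3 has the highest number of the three in this assay and so is the weakest of them. The nearest measured step to it is a 6.9-fold higher number from compound 2 to compound 3 (0.84 log units; beyond the scatter), with butyl in place of 2,4-difluorophenyl on a sulfonyl sulfur.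

Compound 4 `CCCCS(=O)(=O)Nc1cc(-c2ccc3c(c2)N(CCCn2ccccc2=O)C(=O)CO3)cnc1OC` keeps that butyl and differs at another place: a group of 9 heavy atoms (7 carbon, 1 nitrogen, 1 oxygen; one six-membered aromatic ring with 1 hetero atom) in place of a group of 6 heavy atoms (5 carbon, 1 nitrogen; one six-membered aromatic ring with 1 hetero atom), on a saturated chain carbon bound to an amide-type nitrogen in a ring. The step at that place is a 1.1-fold higher number from compound 1 to compound 2 (0.04 log units; within the scatter), with pyridin-4-yl in place of 4-fluorophenyl, and it stays within the scatter. Among the measured compounds shown here, that step was measured with 2,4-difluorophenyl on the sulfonyl sulfur, not butyl, and no measured compound carries the entering group, so the guidance is thin. The butyl step does not apply here, since both compounds share that group.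

No change beyond the scatter is expected in this assay, and the expected step is a 1.2-fold lower number from compound 3 to compound 4 (0.07 log units; within the scatter). Compound 4 is estimated at 32000 nM, with an expected range of 12000 nM to 80000 nM.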

Compound 4, half-maximal inhibitory concentration: 47900 nM
Compound 4: middle estimate off by 1.5-fold (0.18 log units), on the low side; low and high end bracket the measured number.
By their numbers in this assay, from the lowest: compounds 1 and 2 (each within the scatter of the next); then compounds 3 and 4 (each within the scatter of the next).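

In this assay, the group of 9 heavy atoms in place of pyridin-4-yl, on a saturated chain carbon bound to an amide-type nitrogen in a ring, gives a 1.3-fold higher number from compound 3 to compound 4 (0.10 log units; within the scatter), so with butyl on the sulfonyl sulfur this place accepts a larger group without a change beyond the scatter. Together with a 1.1-fold higher number from compound 1 to compound 2 (0.04 log units; within the scatter), measured with 2,4-difluorophenyl on the sulfonyl sulfur, this gives two exchanges at this place, on two different sulfonyl substituents, and neither moves the number beyond the scatter. Nothing available accounts for how little this place changes the number.

As far as these compounds go, it remains open whether the group of 9 heavy atoms would give the same result with 2,4-difluorophenyl on the sulfonyl sulfur. From the compounds shown here alone, it is also open whether a primary amine or a carboxylic acid at this place would shift the number beyond the scatter.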